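The compounds below may be only part of what the source reports. "The series", "measured", "known", "first", "only" and "open" are said of these compounds alone.

Two acylureas sharing one core have been tested in a physicochemical assay for solubility (a higher number here means a more soluble compound, a lower number a less soluble compound), so far. Compound 1, `COc1ccccc1C(=O)NC(=O)Nc1ccc(-c2ccccc2)c(C(C)C)c1`, carries a phenyl group and an isopropyl group on its right-hand ring. In this assay compound 1 returns < 1 ug/mL, which is a limit of the method rather than a number. Compound 2, `COc1ccccc1C(=O)NC(=O)Nc1ccc(OCC(F)(F)F)c(C(F)(F)F)c1`, carries a 2,2,2-trifluoroethoxy group and a trifluoromethyl group instead. In this assay compound 2 also returns < 1 ug/mL, again a limit rather than a number. Both results therefore sit at the limit of < 1 ug/mL in this assay, at which 2 of the 2 values shown sit, so compound 2 stands at the floor of what the method can report, and nothing separates it from compound 1 on the numbers shown.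

Compound 3, `COc1ccccc1C(=O)NC(=O)Nc1ccc(-c2ccccn2)c(C(F)(F)F)c1`, follows from compound 2 by one change: pyridin-2-yl in place of 2,2,2-trifluoroethoxy on an aromatic carbon. For the measured compounds named here, no measured pair in this set tells how such a swap moves solubility, so any expectation rests on the two limits alone. The step from compound 2 to compound 3 is expected to be a number no lower from compound 2 to compound 3 (the limit leaves the size open), a rise that is small or none beyond the scatter. Compound 3 is therefore estimated at 1 ug/mL, with a range from 0.3 ug/mL to 5 ug/mL.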

Compound 3, solubility: 28 ug/mL
For compound 3 the middle estimate is 28-fold (1.45 log units) below the measured one; measured number outside the range, above it.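

In this assay, pyridin-2-yl in place of 2,2,2-trifluoroethoxy, on an aromatic carbon ortho to a trifluoromethyl group, gives an at least 28-fold higher number from compound 2 to compound 3 (1.44 log units; beyond the scatter) and yields the first read-out in this set that is a number and not a limit. The earlier compounds shown here could not show that a change at this place is able to lift a value clear of the limit, and here it happens although the group that leaves and the group that enters have the same counts of heavy atoms and hydrogen-bond acceptors and neither carries a net charge. From the compounds shown here alone, the true size of the step stays unknown, and only its lower bound can be read, since its starting point is a limit of the method and not a number: the limit of < 1 ug/mL in this assay, at which 2 of the 3 values shown sit.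

Going by these compounds, whether the ring nitrogen of pyridin-2-yl matters, or the ring alone, stays open, as compound 1 carries a phenyl group but differs from compound 3 in two places. How an amine or a carboxylic acid at this place would read in this assay also remains unknown from the compounds shown.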